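The source may report more compounds than this note shows. Statements on the series, on what has been measured and on what is new or still open speak of the compounds shown alone.

In a functional assay on K562 cells (Homo sapiens) for cytotoxicity, read by fluorescence, with a stated time of 72 h (a lower number here means a stronger inhibitor, a higher number a weaker inhibitor), compound 1 (`CSc1nc(NCc2ccc(-c3ccccn3)cc2)c2[nH]nc(C(C)C)c2n1`) gives 778 nM, compound 2 (`CC(C)c1n[nH]c2c(NCc3ccc(-c4ccccn4)cc3)nc(NCC(C)(C)O)nc12`) gives 29 nM and compound 3 (`CC(C)c1n[nH]c2c(NCc3ccc(-c4ccccn4)cc3)nc(N3CCCCC3CCO)nc12`) gives 165 nM, so compound 3 holds the second highest of the three numbers. Compound 4 (`CC(C)c1n[nH]c2c(NCc3ccc(-c4ccccn4)cc3)nc(N[C@@H]3CCCC[C@H]3N)nc12`) differs from compound 3 at one place, an aromatic carbon between two ring nitrogen atoms: (2-aminocyclohexyl)amino in place of 2-(2-hydroxyethyl)piperidin-1-yl ((2-aminocyclohexyl)amino in place of 2-(2-hydroxyethyl)piperidin-1-yl on an aromatic carbon). For the measured compounds named here, three measured steps concern this same place: a 27-fold lower number from compound 1 to compound 2 (1.43 log units; beyond the scatter), a 4.7-fold lower number from compound 1 to compound 3 (0.67 log units; beyond the scatter) and a 5.7-fold higher number from compound 2 to compound 3 (0.76 log units; beyond the scatter). The incoming group is an amino-linked one, like that of compound 2 at 29 nM, so a modest move to a lower number is expected. The expected step is a 4.1-fold lower number from compound 3 to compound 4 (0.62 log units; beyond the scatter). For compound 4 the estimated value is 40 nM, within an expected range of 12 nM to 130 nM.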

Compound 4, half-maximal inhibitory concentration: 175 nM
Compound 4: the middle estimate sits 4.4-fold (0.64 log units) below what was measured; the whole stated range lies below it.
By their numbers in this assay, from the lowest: compound 2; then compounds 3 and 4 (each within the scatter of the next); then compound 1.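

In this assay and with an amino link kept at this aromatic carbon, 2-aminocyclohexyl in place of 2-hydroxy-2-methylpropyl gives a 6.0-fold higher number from compound 2 to compound 4 (0.78 log units; beyond the scatter) so the link alone does not hold the low number of compound 2. The change from 2-(2-hydroxyethyl)piperidin-1-yl gives a 1.1-fold higher number from compound 3 to compound 4 (0.03 log units; within the scatter) and the change from methylsulfanyl gives a 4.4-fold lower number from compound 1 to compound 4 (0.65 log units; beyond the scatter) so compound 3 and compound 4 read alike despite their different links. Nothing available explains this result.

On these data alone, it remains open whether a hydroxyl in place of the ring amine, or an open chain such as 2-aminoethyl, would return to the level of compound 2. As far as these compounds go, the other stereoisomers of the 2-aminocyclohexyl group also remain open.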